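The source may hold more compounds than are shown below. What is called first, only, known or untested is meant among the compounds shown, and "the series" means these compounds.

Compound 1 `CO[C@@H](C(=O)NC1CC[C@@H](OC(=O)C2CCCC2)CNC1=O)[C@H](O)[C@@H](O)[C@H](O)/C=C/C(C)(C)C` — 130 nM
Compound 2 `CCCCCCCCCCOc1ccc(C(=O)O[C@@H]2CCC(NC(=O)[C@H](OC)[C@H](O)[C@@H](O)[C@H](O)/C=C/C(C)(C)C)C(=O)NC2)cc1` — 10 nM
Compound 3 `CCCCCCCCCCc1ccc(C(=O)O[C@@H]2CCC(NC(=O)[C@H](OC)[C@H](O)[C@@H](O)[C@H](O)/C=C/C(C)(C)C)C(=O)NC2)cc1` — 30 nM

Of the compounds shown here, three have been measured in an in vivo functional assay on the whole organism (MDA-MB-435 cells, Homo sapiens) for antiproliferative activity; on this read-out lower numbers stand for stronger inhibition and higher numbers for weaker inhibition. Compound 1 gives the highest number of the three; compound 3 sits nearest to it with 30 nM, and compound 2 furthest with 10 nM. Among the compounds with values here, the one measured step between compounds that differ in a single place is a 3.0-fold higher number from compound 2 to compound 3 (0.48 log units; beyond the scatter).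

Compound 4 `CO[C@@H](C(=O)NC1CC[C@@H](OC(=O)C2CCCCC2)CNC1=O)[C@H](O)[C@@H](O)[C@H](O)/C=C/C(C)(C)C` differs from compound 1 in one place: cyclohexyl in place of cyclopentyl on a carbonyl carbon. Within the data shown here, no measured step bears on this change. Among the measured compounds shown here, the step from compound 2 to compound 3 concerns a decyloxy group on an aromatic carbon, and compounds 2 and 3 carry an aromatic ester where compound 1 carries the cyclopentyl ester, so their values show only that a different ester group can go with a lower number in this assay; neither speaks to the ring-size change itself. For compound 4 the expected step is therefore none beyond the scatter, with no direction favoured: a 1.2-fold lower number from compound 1 to compound 4 (0.07 log units; within the scatter). Compound 4 is expected at 110 nM, within a range of 40 nM to 300 nM.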

Compound 4, half-maximal inhibitory concentration: 4 nM
Compound 4: middle estimate off by 28-fold (1.44 log units), on the high side; measured number outside the range, below it.
By their numbers in this assay, from the lowest: compound 4; then compound 2; then compound 3; then compound 1.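

In this assay, the ester group on the shared core turns out to be very sensitive to ring size: cyclohexyl in place of cyclopentyl on a carbonyl carbon gives a 33-fold lower number from compound 1 to compound 4 (1.51 log units; beyond the scatter), although the change only takes the group from 5 heavy atoms to 6, with no hydrogen-bond donors or acceptors on either side. Within the data shown here, the only earlier step, a 3.0-fold higher number from compound 2 to compound 3 (0.48 log units; beyond the scatter), concerned a decyloxy group on an aromatic carbon and gave no sign that so small a change at the carbonyl carbon could matter this much; with compound 4 at 4 nM, a decyl or decyloxy chain on an aromatic ester is also not the only route to a low number. Nothing available on these compounds accounts for a step of this size at this place.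

Open, as far as these compounds go, is whether the effect is specific to cyclohexyl or continues with a cycloheptyl ring, and how an open-chain ester such as a pivaloyl group would compare. A piperidine ring or a cyclohexyl ring carrying a hydroxyl group at the same place would show whether this position tolerates anything other than a ring of carbon only.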